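Swapping formyl for vinyl on compound 3

The compounds below may be only part of what the source reports. "The series", "measured", "known", "first", "only" and "open" are said of these compounds alone.

Measured in a functional assay on SK-OV-3 cells (Homo sapiens) for cytotoxicity, read by MTT assay, with a stated time of 48 h; on this read-out lower numbers stand for stronger inhibition and higher numbers for weaker inhibition:
Compound 1 `C=CCn1c(-c2ccc(OC)cc2COCOC)cc2ccccc2c1=O`: > 100000 nM
Compound 2 `C=CCn1c(-c2cc(OC)c(OC)cc2C=C)cc2ccccc2c1=O`: 35500 nM
Compound 3 `C=CCn1c(-c2ccc(OC)cc2C=O)cc2ccccc2c1=O`: 65500 nM

The entry for compound 1 is a limit and not a true number: the limit of > 100000 nM in this assay, at which 1 of the 3 values shown sits. Among the compounds with values here, compound 3 gives 65500 nM, which lies within the usual scatter of the only other true number, the one for compound 2.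

The next molecule is compound 4 `C=CCn1c(-c2ccc(OC)cc2C=C)cc2ccccc2c1=O`. It differs from compound 3 in one place, with vinyl in place of formyl on an aromatic carbon.

Within the data shown here, only one measured step touches this same place: an at least 1.5-fold lower number from compound 1 to compound 3 (0.18 log units; that floor lies within the scatter). That step put formyl in place of (methoxymethoxy)methyl and starts from a limit, so it gives no true size. Among the measured compounds shown here, no measured step shows the exchange of formyl for vinyl itself. Compound 2, which also carries a vinyl group, gives 35500 nM, and that value stays within the scatter of compound 3. No step beyond the scatter is therefore expected in this assay, with at most a slight drift towards the value of compound 2. The expected move is a 1.5-fold lower number from compound 3 to compound 4 (0.16 log units; within the scatter). Expected for compound 4 is 45000 nM, within an estimated range of 18000 nM to 100000 nM.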

Compound 4, half-maximal inhibitory concentration: 43800 nM
Beside the measured number, compound 4's estimate is 1.0-fold (0.01 log units) above it, within the range that was stated.
By their numbers in this assay, from the lowest: compounds 2, 4 and 3 (each within the scatter of the next). At a limit, above all of these: compound 1.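

In this assay, within the data shown here, the exchange of formyl for vinyl on this aromatic carbon, ortho to a large group, is the first step at this position measured between two true numbers, and it stays within the scatter: a 1.5-fold lower number from compound 3 to compound 4 (0.17 log units; within the scatter). Hydrogen in place of methoxy on the same ring also cannot be told apart from the scatter, with a 1.2-fold higher number from compound 2 to compound 4 (0.09 log units; within the scatter), so compound 2 and compound 4 read as one level. Only vinyl in place of (methoxymethoxy)methyl goes beyond the scatter, with an at least 2.2-fold lower number from compound 1 to compound 4 (0.35 log units; beyond the scatter), and that size is only a floor, for compound 1 stands at a limit and not at a true number: the limit of > 100000 nM in this assay, at which 1 of the 4 values shown sits.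

Going by these compounds, whether a different kind of group on this aromatic carbon, such as an amine, a carboxylic acid or a longer carbon chain, would move the number beyond the scatter remains open. Also open is which part of the shared core matters for the cytotoxicity on these cells, as the changes shown touch only the groups on one aromatic ring.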